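A few compounds are considered here, and "the series" means these few. Any claim that something is new, unique, unknown or untested is made for them only; others in the source may bear on it.

In an ADME assay on microsomes from liver (Homo sapiens) for metabolic stability, read by LC-MS, with a stated time of 10 min, tested at 0.5 uM (a lower number here means that less of the compound is left, a higher number that more of the compound is left), compound 1 `c1ccc2c(c1)CN[C@@H](CN(CC[C@H]1CCCNC1)[C@H]1CCCc3cccnc31)C2` gives 93%, the second highest of the three numbers recorded. Compound 2 `c1ccc2c(c1)CN[C@@H](CN(CCCN1CCNCC1)[C@H]1CCCc3cccnc31)C2` gives 100% in this assay, and compound 3 `c1ccc2c(c1)CN[C@@H](CN(CC[C@@H]1CCCNC1)[C@H]1CCCc3cccnc31)C2` gives 75%. The change a number 7 percentage points higher from compound 1 to compound 2 (within the scatter) stays within the usual scatter, whereas a number 18 percentage points lower from compound 1 to compound 3 (beyond the scatter) lies beyond it, a difference that rests on (the fact that compounds 1 and 3 differ only in the configuration as drawn). Compound 4 `NC(=O)N1CCN(CCCN(C[C@H]2Cc3ccccc3CN2)[C@H]2CCCc3cccnc32)CC1` carries a further change at the same position: (4-carbamoylpiperazin-1-yl)methyl in place of piperidin-3-yl on a saturated chain carbon, two bonds along the chain from an amine nitrogen. The measured step from compound 1 to compound 2 is the one that bears on it most closely, and it was small, so no movement beyond the scatter is expected for compound 4 in this assay. Compound 4 is therefore estimated at 94%, within 80% to 100%, a step of a number 1 percentage points higher from compound 1 to compound 4 (within the scatter).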

Compound 4, percent of the compound remaining: 79%
Compound 4: the middle estimate sits 15 percentage points above what was measured; measured number below the stated range.
By their numbers in this assay, from the lowest: compounds 3 and 4 (each within the scatter of the next); then compounds 1 and 2 (each within the scatter of the next).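

In this assay, the carbamoyl on the ring amine nitrogen gives a number 21 percentage points lower from compound 2 to compound 4 (beyond the scatter), so the match between the (piperazin-1-yl)methyl and piperidin-3-yl groups does not survive substitution on that ring. Against the piperidin-3-yl compounds, the new group gives a number 14 percentage points lower from compound 1 to compound 4 (beyond the scatter) but a number 4 percentage points higher from compound 3 to compound 4 (within the scatter), so the comparison depends on which configuration is taken as the reference. Nothing at hand explains the loss seen with the carbamoyl group. Going by these compounds, it remains open whether a methyl or an acetyl group on that ring nitrogen would behave like the hydrogen of compound 2 or the carbamoyl of compound 4.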